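This account rests on a few compounds, and the source may have more. Where it says the series, first, only, none or still open, it means among the compounds named here.

Compound 1 `COc1cc(/C=C/C(=O)c2cccc(-n3cc(-c4ccccc4)[nH]c3=O)c2)cc(OC)c1OC`: 2090 nM
Compound 2 `COc1ccc(-c2cn(-c3cccc(C(=O)/C=C/c4ccc(O)c(OC)c4)c3)c(=O)[nH]2)cc1`: 4110 nM

Both compounds were tested in a functional assay on SN12C cells (Homo sapiens) for inhibition; a higher number here means a weaker inhibitor of growth, a lower number a stronger inhibitor of growth. In this assay compound 1 gives 2090 nM, and compound 2 gives 4110 nM. Compound 2 thus carries the higher of the two numbers shown, but its nearest neighbour is compound 1 and the gap between them lies within the usual scatter, so the two cannot be separated on these data. Within the data shown here, compounds 1 and 2 differ from each other in more than one place, so no single-change step between measured compounds is available.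

The next compound, compound 3 `COc1ccc(-c2cn(-c3cccc(C(=O)/C=C/c4cc(OC)c(OC)c(OC)c4)c3)c(=O)[nH]2)cc1`, has not yet been measured. It differs from compound 2 in one place: 3,4,5-trimethoxyphenyl in place of 4-hydroxy-3-methoxyphenyl on a double-bonded chain carbon bound to a double-bonded chain carbon. Compound 1 carries the same 3,4,5-trimethoxyphenyl group on its chain, which gives some footing for an expectation. The step of a 1.6-fold lower number from compound 2 to compound 3 (0.22 log units; within the scatter) is expected to be small, toward a somewhat lower number, and quite possibly not beyond the scatter. Compound 3 is therefore estimated at 2500 nM, in a range from 900 nM to 7000 nM, a guess anchored because compound 1 gives 2090 nM with the same group on the chain.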

Compound 3, concentration for 50% growth inhibition: 3500 nM
Compound 3: the middle estimate sits 1.4-fold (0.15 log units) below what was measured; low and high end bracket the measured number.
By their numbers in this assay, from the lowest: compounds 1, 3 and 2 (each within the scatter of the next).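

Replacing 4-hydroxy-3-methoxyphenyl with 3,4,5-trimethoxyphenyl on a double-bonded chain carbon bound to a double-bonded chain carbon gives a 1.2-fold lower number from compound 2 to compound 3 (0.07 log units; within the scatter) in this assay. Among these compounds, this is the first direct reading at this place, and it shows that the hydrogen-bond donor of the leaving group can be given up, and the larger group accepted, with no change that these data can separate from the scatter. The second single change, methoxy in place of hydrogen on an aromatic carbon, gives a 1.7-fold higher number from compound 1 to compound 3 (0.22 log units; within the scatter) and so also stays within the scatter, which means neither step moves the number measurably. No supporting measurement bears on these results, so nothing can be said about what lies behind them.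

The compounds shown leave open whether a group of a different kind on the chain, such as a carboxylic acid or a dimethylamino-substituted phenyl, would produce a step beyond the scatter. They also leave open whether a fluorine or a chlorine in place of the methoxy on the aromatic carbon would do so.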